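A few compounds are considered here, and "the series" means these few. Any claim that something is new, unique, unknown or untested is made for them only; others in the source may bear on it.

Of the compounds shown here, three sharing one core have been read in a functional assay on DU-145 cells (Homo sapiens) for inhibition, read by MTT assay, with a stated time of 72 h; on this read-out higher numbers stand for weaker inhibition and lower numbers for stronger inhibition. Compound 1 `O=C1C=C(N2CCN(c3ccc(Br)cc3)CC2)C(=O)c2ccccc21` gives > 50000 nM, which is a limit of the assay and not a number. Compound 2 `O=C1C=C(N2CCN(c3cccc(Cl)c3)CC2)C(=O)c2ccccc21` gives 8300 nM, and compound 3 `COc1ccccc1N1CCN(C2=CC(=O)c3ccccc3C2=O)CC1` gives 8000 nM. The step of a 1.0-fold lower number from compound 2 to compound 3 (0.02 log units; within the scatter) shows that these two cannot be told apart, so compound 3 shares its standing with compound 2, and both are clear of the limit.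

Compound 4 `O=C1C=C(N2CCN(c3ccc(F)c(Cl)c3)CC2)C(=O)c2ccccc21` has not yet been measured. It places 3-chloro-4-fluorophenyl where compound 3 has 2-methoxyphenyl, on an amine nitrogen in a ring: 3-chloro-4-fluorophenyl in place of 2-methoxyphenyl on an amine nitrogen in a ring. Two measured steps start from the 4-bromophenyl of compound 1, namely an at least 6.0-fold lower number from compound 1 to compound 2 (0.77 log units; beyond the scatter) and an at least 6.2-fold lower number from compound 1 to compound 3 (0.79 log units; beyond the scatter). The entering group keeps the 3-chloro feature of compound 2, which points to a number close to compound 3, given the step of a 1.0-fold lower number from compound 2 to compound 3 (0.02 log units; within the scatter). Going by the values given here, its 4-fluoro feature loosely recalls the 4-bromophenyl of compound 1, but no measured step isolates it. A small move toward a higher number is therefore expected, at most slightly beyond the scatter: a 1.5-fold higher number from compound 3 to compound 4 (0.18 log units; within the scatter). For compound 4 the estimated value is 12000 nM, with an expected range from 4000 nM to 40000 nM.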

Compound 4, half-maximal inhibitory concentration: 32200 nM
The estimate for compound 4 lay 2.7-fold (0.43 log units) below the measured number, within the range that was stated.
By their numbers in this assay, from the lowest: compounds 3 and 2 (each within the scatter of the next); then compound 4. At a limit, above all of these: compound 1.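

In this assay, going by these compounds alone, compounds 2 and 4 differ in one place only, and a 3.9-fold higher number from compound 2 to compound 4 (0.59 log units; beyond the scatter) gives the first measured step that isolates a fluoro group on this aryl ring: fluoro in place of hydrogen on an aromatic carbon moves the number beyond the scatter, towards weaker inhibition. The step of a 4.0-fold higher number from compound 3 to compound 4 (0.60 log units; beyond the scatter) shows that the level reading of the 2-methoxyphenyl and 3-chlorophenyl groups does not extend to every substituted phenyl on this amine nitrogen, since the 3-chloro-4-fluorophenyl group of compound 4 reads apart from both. Compound 1 stands at a limit and not at a number, and an at least 1.5-fold lower number from compound 1 to compound 4 (0.19 log units; that floor lies within the scatter) does not separate compound 4 from it: the limit of > 50000 nM in this assay, at which 1 of the 4 values shown sits.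

As far as these compounds go, whether an unsubstituted phenyl, a 4-methoxyphenyl or a benzyl group on the same amine nitrogen would read nearer compound 3 or nearer compound 4 remains open. Also open, from the compounds shown here alone, is whether a fluoro group would bring a step of similar size on the 2-methoxyphenyl ring of compound 3, and the numbers give no cause for any of these steps.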